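An Open Chain in Place of a Ring

The source may hold more compounds than are shown below. What is called first, only, known or untested is meant among the compounds shown, and "the series" means these compounds.

Compound 1 `COc1c(N2CC[C@@H](CO)C2)c(F)cc2c(=O)c(C(=O)O)cn(Cc3ccc(-c4ccccc4)cc3)c12` belongs to a small set of quinolone-like acids tested in an assay on isolated protein for inhibition of DNA topoisomerase 1 (Homo sapiens), with a stated time of 15 min, tested at 200 uM; on this read-out higher numbers stand for more inhibition at the one concentration tested (going by the name of the read-out) and lower numbers for less inhibition. In this assay compound 1 gives 10%. Its closest neighbour on the numbers is compound 2 `COc1c(N2CC[C@@H](CN)C2)c(F)cc2c(=O)c(C(=O)O)cn(Cc3ccc(-n4cccn4)cc3)c12`, which in this assay gives 10%; the two stand level within the usual scatter, so neither can be called the stronger. A third entry, compound 3 `CNC(=O)c1cn(Cc2ccc(-c3ccccc3)cc2)c2c(OC)c(NC)c(F)cc2c1=O`, is reported in this assay only as "not active" (no number reported), with no number attached. Among the compounds with values here, on the whole, the number for compound 1 in this assay is low, and no step between measured compounds is available to show how any single change moves the read-out.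

The compound to be measured next is compound 4 `COc1c(NCCN)c(F)cc2c(=O)c(C(=O)O)cn(Cc3ccc(-c4ccccc4)cc3)c12`. It differs from compound 1 in one place: (2-aminoethyl)amino in place of 3-(hydroxymethyl)pyrrolidin-1-yl on an aromatic carbon. Within the data shown here, with all numbers so far lying low and close together, the expected step from compound 1 to compound 4 in this assay is small, none beyond the scatter, estimated as no change at the digits printed from compound 1 to compound 4 (within the scatter). Compound 4 is therefore expected to give about 10% in this assay, with a plausible range from 0% to 25%.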

Compound 4, a percentage reported as inhibition, at one concentration (the size of the read-out at that concentration, not a potency): 10%
Compound 4: middle estimate and measured number agree at the digits printed, within the range that was stated.
By their numbers in this assay, from the lowest: compounds 1, 2 and 4 (each within the scatter of the next).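

In this assay, replacing 3-(hydroxymethyl)pyrrolidin-1-yl with (2-aminoethyl)amino on this aromatic carbon gives no change at the digits printed from compound 1 to compound 4 (within the scatter). Within the data shown here, this is the first single-place comparison in the set, and it is a large change in structure: the five-membered ring and the defined stereocentre both go, the hydroxyl gives way to an amine, and the open chain has fewer heavy atoms. Even so, the read-out does not separate the two groups at the one concentration tested, and nothing measured here explains why the value holds steady.

This single pair cannot show whether the ring, the stereocentre and the hydroxyl each have no effect, or whether their separate effects happen to cancel. On these data alone, it also remains open whether a longer chain such as (3-aminopropyl)amino, a carboxylic acid at the end of the chain, or a piperazine ring at this aromatic carbon would lift the inhibition clearly above the low level seen so far.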